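The source may hold more compounds than are shown below. What is called first, only, known or untested is meant among the compounds shown, and "the series" means these compounds.

Measured so far in a functional assay on HepG2 cells (Homo sapiens) for cytotoxicity, read by MTT assay, with a stated time of 24 h; a lower number here means a stronger inhibitor, a higher number a weaker inhibitor:

- compound 1 `COc1ccc(/C=C2\CN(C)C/C(=C\c3ccccc3F)C2=O)cc1`: 12300 nM
- compound 2 `CN1C/C(=C\c2ccc(C(C)(C)C)cc2)C(=O)/C(=C/c2ccccc2F)C1`: 9120 nM
- compound 3 `CN1C/C(=C\c2ccc(C(F)(F)F)cc2)C(=O)/C(=C/c2ccccc2F)C1`: 4140 nM

Among these three, compound 3 has the lowest number, 4140 nM, and its gaps to the other two lie beyond the scatter. The next molecule, compound 4 `CN1C/C(=C\c2ccc(C(F)(F)F)cc2)C(=O)/C(=C/c2cccc([N+](=O)[O-])c2)C1`, keeps the trifluoromethyl group of compound 3 and changes the other end of the molecule: 3-nitrophenyl in place of 2-fluorophenyl on a double-bonded chain carbon bound to a double-bonded ring carbon. In short, 3-nitrophenyl takes the place of 2-fluorophenyl on a double-bonded chain carbon bound to a double-bonded ring carbon.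

The measured steps offer only indirect guidance. All three swap a group on an aromatic carbon while 2-fluorophenyl stays in place, so none tests this site. They do show how far single swaps have moved the number in this assay: a 1.3-fold lower number from compound 1 to compound 2 (0.13 log units; within the scatter), a 2.2-fold lower number from compound 2 to compound 3 (0.34 log units; beyond the scatter) and a 3.0-fold lower number from compound 1 to compound 3 (0.47 log units; beyond the scatter). The last of these is the largest, and it is still modest. Going by the values given here, with no measured example of this swap, no direction can be read from the data, so no step beyond the scatter is expected, though a modest move either way remains possible. This estimate corresponds to an expected 1.0-fold lower number from compound 3 to compound 4 (0.01 log units; within the scatter). The estimated value for compound 4 is 4000 nM, with an expected range from 1500 nM to 11000 nM.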

Compound 4, half-maximal inhibitory concentration: 1040 nM
The estimate for compound 4 lay 3.8-fold (0.59 log units) above the measured number; measured number below the stated range.
By their numbers in this assay, from the lowest: compound 4; then compound 3; then compounds 2 and 1 (each within the scatter of the next).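

In this assay, the swap of 2-fluorophenyl for 3-nitrophenyl on a double-bonded chain carbon bound to a double-bonded ring carbon gives a 4.0-fold lower number from compound 3 to compound 4 (0.60 log units; beyond the scatter) and is the largest single step among the compounds shown, though still modest. Going by these compounds alone, all the earlier steps kept 2-fluorophenyl in place, so only now is it clear that this site also affects the number and that a group with more heavy atoms and two hydrogen-bond acceptors is compatible with a lower number. Nothing measured here explains why the number fell, so the step remains an observation without a known cause.

Two things changed together in this swap, since the fluorine left and the nitro group entered, so the compounds shown cannot separate the loss of one from the gain of the other, and a plain phenyl or a 3-aminophenyl group at this place would help to pull the two apart. On these data alone, it also remains open whether 3-nitrophenyl would give a similar step alongside methoxy or tert-butyl, as it appears here only in a compound carrying trifluoromethyl.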